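A chloro to methyl swap at the limit

A few compounds are considered here, and "the series" means these few. Any claim that something is new, unique, unknown or untested is made for them only; others in the source may bear on it.

In a physicochemical assay for solubility, in phosphate buffer, at pH 7.4 (on this read-out lower numbers stand for lower solubility and higher numbers for higher solubility), compound 3 (`CCOC(=O)c1c(-c2cccc(Cl)c2)[nH]c2cccc(OC)c2c1=O`) gives > 100000 nM as its reading, which is a limit and not a number. Compound 1 (`CCOC(=O)c1c(-c2cccc(F)c2)[nH]c2cc(OC)ccc2c1=O`) gives > 100000 nM in this assay as its reading, again a limit. Together these two make up the limit of > 100000 nM in this assay, at which 2 of the 3 values shown sit, and neither has an exact figure. Compound 2 (`CCOC(=O)c1c(-c2cccc(C(F)(F)F)c2)[nH]c2cc(OC)ccc2c1=O`) has a measured number, 19000 nM in this assay on the same scale.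

Compound 4 (`CCOC(=O)c1c(-c2cccc(C)c2)[nH]c2cccc(OC)c2c1=O`), not yet measured, carries methyl in place of chloro on an aromatic carbon, so that 3-chlorophenyl becomes 3-methylphenyl (methyl in place of chloro on an aromatic carbon). Going by the values given here, only one measured step bears on this change: an at least 5.2-fold lower number from compound 1 to compound 2 (0.72 log units; beyond the scatter) for trifluoromethyl in place of fluoro on an aromatic carbon. That was a different exchange, made on the core of compound 1 rather than that of compound 3, and it is bounded on one side only, so it offers weak guidance. No step beyond the scatter is therefore expected, although a fall towards the reading of compound 2 remains possible. The expected step is a number no higher from compound 3 to compound 4 (the limit leaves the size open) in this assay on this reasoning. Compound 4 is estimated at 100000 nM in this assay, with an expected range from 30000 nM to 200000 nM and a good chance of another limit.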

Compound 4, solubility: > 100000 nM
Compound 4 ended at the assay's limit; the forecaster's own chance of this, stated with the estimate: 60%; the middle value lies on the limit itself.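

Compound 3 and compound 4 both ended at a limit in this assay and not at a number, so no step can be read between them: the limit of > 100000 nM in this assay, at which 3 of the 4 values shown sit.

The compounds shown leave open whether methyl in place of chloro on an aromatic carbon changes the reading on the core of compound 3 at all, and in which direction.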